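Aryl Urea Quinoline Ethers: Swapping Trifluoromethyl for Chloro

The source may report more compounds than this note shows. Statements on the series, on what has been measured and on what is new or still open speak of the compounds shown alone.

Compound 1: `COc1cc2cc(Oc3ccc(NC(=O)Nc4cccc(C(F)(F)F)c4)cc3)c(C)nc2cc1OC` — 2280 nM
Compound 2: `COc1cc2cc(Oc3ccc(NC(=O)Nc4ccc(Cl)c(C(F)(F)F)c4)cc3)c(C)nc2cc1OC` — 1250 nM

The two compounds share a core and differ only in the aryl urea terminus. In a functional assay on SW-620 cells (Homo sapiens) for inhibition, read by sulforhodamine B assay, with a stated time of 48 h (a higher number here means a weaker inhibitor of growth, a lower number a stronger inhibitor of growth), compound 1 gives 2280 nM and compound 2 gives 1250 nM, a step of a 1.8-fold lower number from compound 1 to compound 2 (0.26 log units; within the scatter). Compound 2 thus holds the lower of the two numbers, but within the scatter of compound 1, so no order between them can be claimed.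

Compound 3 is `COc1cc2cc(Oc3ccc(NC(=O)Nc4ccc(Cl)c(Cl)c4)cc3)c(C)nc2cc1OC`. Its change from compound 2 is chloro in place of trifluoromethyl on an aromatic carbon. For the measured compounds named here, no measured step matches this exchange; the only step available, from compound 1 to compound 2, added a chloro in place of hydrogen and stayed within the scatter. On that basis a step of a 1.2-fold higher number from compound 2 to compound 3 (0.08 log units; within the scatter) is expected, with no direction beyond the scatter. Compound 3 is estimated at 1500 nM in this assay, between 600 nM and 4000 nM.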

Compound 3, concentration for 50% growth inhibition: 4240 nM
The estimate for compound 3 lay 2.8-fold (0.45 log units) below the measured number; the whole stated range lies below it.
By their numbers in this assay, from the lowest: compounds 2, 1 and 3 (each within the scatter of the next, the first and the last beyond it).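

In this assay, for the compounds shown here, chloro in place of trifluoromethyl on the aromatic carbon ortho to a chloro group gives a clear change (a 3.4-fold higher number from compound 2 to compound 3 (0.53 log units; beyond the scatter)), the first step beyond the scatter, so the group at this position does register in the read-out. The comparison of the 3,4-dichlorophenyl and 3-(trifluoromethyl)phenyl termini shows no such separation (a 1.9-fold higher number from compound 1 to compound 3 (0.27 log units; within the scatter)), so the effect of this exchange can be read only with the 4-chloro-3-(trifluoromethyl)phenyl terminus as its starting point. No measurement is available that explains the difference between trifluoromethyl and chloro here.

The compounds shown leave open how a methoxy group, a nitrile or an amine would behave at this position. They also leave open whether a 3-chlorophenyl terminus would show a comparable step from compound 1.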